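Side-chain change at the limit of the assay

The compounds below may be only part of what the source reports. "The series", "measured", "known", "first", "only" and "open" are said of these compounds alone.

Among the compounds with values here, in a functional assay on HOS cells (Homo sapiens) for antiproliferative activity, read by sulforhodamine B assay (a lower number here means a stronger inhibitor of growth, a higher number a weaker inhibitor of growth), compound 1 (`C=CC[C@@H]1O[C@H](COCc2ccccc2)[C@@H](OCc2ccccc2)[C@H](OCc2ccccc2)[C@H]1O`) gives 44100 nM as the only actual number. Compound 2 (`OCCC[C@@H]1O[C@H](COCc2ccccc2)[C@@H](OCc2ccccc2)[C@H](OCc2ccccc2)[C@H]1O`) gives > 50000 nM which is a limit of the assay and not a number. Compound 3 (`O[C@@H]1[C@@H](OCc2ccccc2)[C@H](OCc2ccccc2)[C@@H](COCc2ccccc2)O[C@H]1CC1CCCCC1`) differs from compound 2 by cyclohexyl in place of 2-hydroxyethyl on a saturated chain carbon bound to a saturated ring carbon with cyclohexyl in place of 2-hydroxyethyl on a saturated chain carbon bound to a saturated ring carbon. Within the data shown here, the one measured step that bears on this is an at least 1.1-fold higher number from compound 1 to compound 2 (0.05 log units; that floor lies within the scatter) and it gives no firm size. Only a small move toward a lower number is therefore expected, and the estimated step is an at least 1.4-fold lower number from compound 2 to compound 3 (0.15 log units; that floor lies within the scatter) with a reading at the limit still possible. Compound 3 is estimated at 35000 nM with 12000 nM to 50000 nM as the expected range.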

Compound 3, concentration for 50% growth inhibition: 4400 nM
The estimate for compound 3 lay 8.0-fold (0.90 log units) above the measured number, and the stated range ends above it.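

Cyclohexyl in place of 2-hydroxyethyl gives an at least 11-fold lower number from compound 2 to compound 3 (1.05 log units; beyond the scatter), and cyclohexyl in place of vinyl gives a 10-fold lower number from compound 1 to compound 3 (1.00 log units; beyond the scatter), so the side chain on this saturated chain carbon can move this assay beyond the scatter, which compound 1 and compound 2 alone did not show. The first of these steps is only a floor, since it rests on a limit of the assay and not a number: the limit of > 50000 nM in this assay, at which 1 of the 3 values shown sits.

The compounds shown do not tell whether the ring itself matters or only the size of the group. A straight hexyl chain, a phenyl ring or an amine at the same place would separate these readings.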